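This account rests on a few compounds, and the source may have more. Where it says the series, first, only, none or still open, it means among the compounds named here.

Compound 2 `CNC(=O)c1ccc(-c2cnc3nnn(C(C)c4cc5cc(-c6cnn(C)c6)cnc5cc4F)c3n2)cc1F` gives the higher of the two numbers in an ADME assay on microsomes from liver (Mus musculus) for metabolic stability, read by LC-MS, using NADPH, with stated times of 5 min and 30 min, tested at 1 uM (on this read-out lower numbers stand for slow clearance and higher numbers for fast clearance), at 24 uL/min; compound 1 `CC(c1cc2cc(-c3cnn(C)c3)cnc2cc1F)n1nnc2ncc(-c3ccc(C(N)=O)c(F)c3)nc21` gives 6 uL/min. Within the data shown here, the only measured step, a 4.0-fold higher number from compound 1 to compound 2 (0.60 log units; beyond the scatter), corresponds to methyl in place of hydrogen on an amide-type nitrogen. Compound 3 `CNC(=O)c1ccc(-c2cnc3nnn(C(C)c4c(F)cc5ncc(-c6cnn(C)c6)cc5c4F)c3n2)cc1F` differs from compound 2 by fluoro in place of hydrogen on an aromatic carbon. Among the measured compounds shown here, no measured step swaps hydrogen for fluoro on an aromatic carbon, so there is nothing to carry over from the data. For compound 3 the expected step is no change at the digits printed from compound 2 to compound 3 (within the scatter). Compound 3 is estimated at 24 uL/min, between 12 uL/min and 48 uL/min.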

Compound 3, intrinsic clearance in a liver preparation (reported as CLH), per the amount of preparation that the assay uses: 187 uL/min
Estimate against measurement, compound 3: 7.8-fold (0.89 log units) below; measured number outside the range, above it.
By their numbers in this assay, from the lowest: compound 1; then compound 2; then compound 3.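

In this assay, fluoro in place of hydrogen on this aromatic carbon, ortho to a fused ring and ortho to a large group, gives a 7.8-fold higher number from compound 2 to compound 3 (0.89 log units; beyond the scatter) and so moves clearance the unfavourable way. This position is therefore not a silent one: a single added fluorine atom on the core of compound 2 is enough to shift the number beyond the scatter. No measurement shown explains this rise.

As far as these compounds go, whether the rise belongs to fluoro itself or would also come with chloro or methyl at this position stays open. So does whether the same swap would act alike on the primary amide of compound 1.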